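Aryl replacement on the shared core: stability outlook for compound 4

The compounds below may be only part of what the source reports. "The series", "measured", "known", "first", "only" and "open" are said of these compounds alone.

Compound 3 `N#Cc1cccc(N/C(=N\O)c2nonc2SCCNC(=O)CS(N)(=O)=O)c1` is the starting point for the next step. In an ADME assay on microsomes from liver (Homo sapiens) for metabolic stability (on this read-out higher numbers stand for a longer-lived compound and lower numbers for a shorter-lived compound), compound 3 gives > 3 h, which is a limit of the assay and not a number. Compound 1 `NS(=O)(=O)CC(=O)NCCSc1nonc1/C(=N/O)Nc1cccc(C(F)F)c1` in this assay gives > 3 h, likewise a limit. Compound 2 `NS(=O)(=O)CC(=O)NCCSc1nonc1/C(=N/O)Nc1cccc(Br)c1` in this assay gives > 3 h, again a limit. Compound 3 thus stands where every value of the series stands, at the limit of > 3 h in this assay, at which 3 of the 3 values shown sit. The measured steps between these three compounds, a step that the two limits leave unreadable from compound 1 to compound 2, a step that the two limits leave unreadable from compound 1 to compound 3 and a step that the two limits leave unreadable from compound 2 to compound 3, are all left unreadable by the limits, so their sizes are not known.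

Compound 4 `NS(=O)(=O)CC(=O)NCCSc1nonc1/C(=N/O)Nc1ccc(F)c(C(F)F)c1` differs from compound 3 in one place: 3-(difluoromethyl)-4-fluorophenyl in place of 3-cyanophenyl on an amine nitrogen. Within the data shown here, no measured step bears directly on this change, and none of the three unreadable steps sets a size for it. Compound 1, which carries a difluoromethyl group on its aromatic ring, sits at the limit in this assay like the others. The step from compound 3 to compound 4 is therefore expected to be a step that the limit leaves unreadable from compound 3 to compound 4, with no movement beyond the scatter anticipated and a further limit the most likely outcome. Compound 4 is estimated at 4.5 h, within 2.5 h to 9 h.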

Compound 4, half-life: 2.77 h
Estimate against measurement, compound 4: 1.6-fold (0.21 log units) above; measured number inside the range.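

In this assay compound 4 gives 2.77 h, the only value shown that is a number and not a limit, while the others all sit at one: the limit of > 3 h in this assay, at which 3 of the 4 values shown sit.

The replacement of the aryl group on the amine nitrogen now has readable floors, an at least 1.0-fold lower number from compound 3 to compound 4 (0.03 log units; that floor lies within the scatter) and an at least 1.0-fold lower number from compound 2 to compound 4 (0.03 log units; that floor lies within the scatter). Fluoro in place of hydrogen on an aromatic carbon gives an at least 1.0-fold lower number from compound 1 to compound 4 (0.03 log units; that floor lies within the scatter), so none of the three steps is established as a loss beyond the scatter.

As far as these compounds go, the steps among compound 1, compound 2 and compound 3 cannot be read, and the true sizes of the three floors remain unknown. Also open, from the compounds shown here alone, is how a trifluoromethyl or methoxy group on the aromatic ring would read in this assay.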